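Adding a Methoxy Group to Compound 3

The compounds below may be only part of what the source reports. "The series", "measured", "known", "first", "only" and "open" are said of these compounds alone.

Measured compounds:
compound 1, `O=C(N/N=C/c1ccc(O)c(O)c1)c1cccnc1Nc1cccc(C(F)(F)F)c1`, 50.8%
compound 2, `COc1cccc(/C=N/NC(=O)c2cccnc2Nc2cccc(C(F)(F)F)c2)c1`, 58.8%
compound 3, `COc1ccc(/C=N/NC(=O)c2cccnc2Nc2cccc(C(F)(F)F)c2)cc1`, 59.4%

In a functional assay on the whole organism (strain Wistar) for inhibition, with Rattus norvegicus as the target, read by paw edema, with a stated time of 1 h, at a dose of 10 mg/kg by the intraperitoneal route (a lower number here means less inhibition, a higher number more inhibition at the dose given (going by the name of the read-out)), compound 3 gives 59.4%, the highest of the three numbers shown. The steps of a number 0.6 percentage points higher from compound 2 to compound 3 (within the scatter) and a number 8.6 percentage points higher from compound 1 to compound 3 (within the scatter) both lie within the scatter, so no ranking among the three compounds can be claimed. Compound 4, `COc1ccc(/C=N/NC(=O)c2cccnc2Nc2cccc(C(F)(F)F)c2)c(OC)c1`, differs from compound 3 in one place: methoxy in place of hydrogen on an aromatic carbon. For the measured compounds named here, no measured step adds a group at this position. Going by the values given here, the steps that bear on the change are those that vary the aryl substituents on the same carbon: a number 8 percentage points higher from compound 1 to compound 2 (within the scatter), a number 8.6 percentage points higher from compound 1 to compound 3 (within the scatter) and a number 0.6 percentage points higher from compound 2 to compound 3 (within the scatter), all within the scatter. Exchanging or relocating a methoxy group has therefore produced no step beyond the scatter, and a second methoxy group is expected to behave likewise. Compound 4 is expected to show 59% in this assay, with a range from 45% to 72%. The expected step is a number 0.4 percentage points lower from compound 3 to compound 4 (within the scatter), not beyond the scatter.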

Compound 4, a percentage reported as inhibition, in the whole organism at one dose (the size of the read-out at that dose, not a potency): 55.7%
Compound 4: the middle estimate sits 3.3 percentage points above what was measured, and the stated range covers the measured number.
By their numbers in this assay, from the lowest: compounds 1, 4, 2 and 3 (each within the scatter of the next).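

Placing methoxy on this aromatic carbon, ortho to a large group and meta to a methoxy group, gives a number 3.7 percentage points lower from compound 3 to compound 4 (within the scatter) in this assay and is the first measured addition at this position; the added group moves the number by no more than the scatter. The 2,4-dimethoxyphenyl compound also stays within the scatter of the other aryl variants, with a number 3.1 percentage points lower from compound 2 to compound 4 (within the scatter) and a number 4.9 percentage points higher from compound 1 to compound 4 (within the scatter) so the four compounds still cannot be ranked. No measured evidence is available to explain these numbers or link them to any property of the methoxy group.

The compounds shown leave open whether an amine, a carboxylic acid or a longer chain on this carbon would produce a step beyond the scatter. They also leave open how a lone methoxy group here would read, with no methoxy group meta to it.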